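A few compounds are considered here, and "the series" means these few. Any claim that something is new, unique, unknown or untested is made for them only; others in the source may bear on it.

Measured compounds
compound 1 `c1ccc2c(c1)CN[C@@H](CN(CCCCNCc1ccncc1)[C@H]1CCCc3cccnc31)C2` — in a functional assay on cells for agonist activity at C-X-C chemokine receptor type 4 (Homo sapiens), read by fluorescence and calcium flux, with a stated time of 90 s (on this read-out higher numbers stand for an effect only at larger amounts of compound and lower numbers for an effect already at smaller amounts), compound 1 reaches only the assay limit, > 30000 nM
compound 2 `c1ccc2c(c1)CN[C@@H](CN(Cc1ccc(CNC3CCOCC3)cc1)[C@H]1CCCc3cccnc31)C2` — in this assay compound 2 likewise reaches only the assay limit, > 30000 nM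

Going by the values given here, compound 2 stands at the limit, as does the one other value; both sit at the limit of > 30000 nM in this assay, at which 2 of the 2 values shown sit, so no ordering of the two is possible. Compound 3 `c1ccc2c(c1)CN[C@@H](CN(Cc1ccc(CNCc3ccncc3)cc1)[C@H]1CCCc3cccnc31)C2` carries (pyridin-4-yl)methyl in place of oxan-4-yl on an amine nitrogen. With both neighbours at the limit, no step beyond the scatter can be expected in this assay, and the change a step that the limit leaves unreadable from compound 2 to compound 3 is only a guess. Compound 3 is expected to give about 40000 nM, within 10000 nM to 150000 nM, most likely again only a limit.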

Compound 3, half-maximal effective concentration: > 30000 nM
Compound 3: only a limit was reported; the forecaster's own chance of this, stated with the estimate: 85%; the middle value is on the limit's open side.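

Compound 2 and compound 3 both reach only a limit, so no step can be read between them: the limit of > 30000 nM in this assay, at which 3 of the 3 values shown sit.

The compounds shown leave open whether (pyridin-4-yl)methyl in place of oxan-4-yl changes agonist potency in this assay at all.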